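Benzyl to 4-methylphenyl on the shared core: compound 4

The source may report more compounds than this note shows. Statements on the series, on what has been measured and on what is new or still open speak of the compounds shown alone.

Measured so far in a functional assay on L1210 cells (Mus musculus) for inhibition, read by cell counting, with a stated time of 2 days; on this read-out lower numbers stand for stronger inhibition and higher numbers for weaker inhibition:
compound 1 `CCOc1ccc(-c2nn3cc(-c4cccc(N)c4)nc3s2)cc1` gives 155000 nM
compound 2 `Nc1cccc(-c2cn3nc(Cc4ccccc4)sc3n2)c1` gives 7400 nM
compound 3 `COc1cccc(Cc2nn3cc(-c4cccc(N)c4)nc3s2)c1` gives 21000 nM

Compound 2 has the lowest number of the three in this assay. Compound 3 sits nearest to it, a 2.8-fold higher number from compound 2 to compound 3 (0.45 log units; beyond the scatter). Among the measured compounds shown here, compound 1, the only member carrying an aryl group bound directly to the shared core rather than through a benzyl linker, sits furthest away; no single-place step connects it to compound 2, so its value is read only as it stands beside that of compound 2.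

Compound 4 `Cc1ccc(-c2nn3cc(-c4cccc(N)c4)nc3s2)cc1` is not yet measured. Its change from compound 2 is 4-methylphenyl in place of benzyl on an aromatic carbon. For the measured compounds named here, the one measured single-place step, from compound 2 to compound 3, concerns a substituent on the benzyl group and bears on this change only loosely. The closer comparison is the pair of compound 1 and compound 2, which differ in the same way as compound 4 does from compound 2 plus the group on the phenyl ring; that pair shows a wide gap.

Compound 4 is therefore expected to move well beyond the scatter toward weaker inhibition, an estimated step of an 8.1-fold higher number from compound 2 to compound 4 (0.91 log units; beyond the scatter). Compound 4 is expected to give about 60000 nM, in the range 15000 nM to 200000 nM.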

Compound 4, half-maximal inhibitory concentration: 4800 nM
Compound 4: middle estimate off by 13-fold (1.10 log units), on the high side, outside the stated range (below it).
By their numbers in this assay, from the lowest: compounds 4 and 2 (each within the scatter of the next); then compound 3; then compound 1.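

In this assay the step from benzyl to 4-methylphenyl on the aromatic carbon of the shared core lies within the scatter, as a 1.5-fold lower number from compound 2 to compound 4 (0.19 log units; within the scatter) shows, so a benzyl group and a directly attached aryl group are not told apart at this place in this pair. Direct attachment of the aryl group therefore does not by itself go with a high number, since compound 4 carries it too; the large step is the one with methyl in place of ethoxy on that aryl group, which is a 32-fold lower number from compound 1 to compound 4 (1.51 log units; beyond the scatter) and rests on this single pair. No measurement on these groups bears on either step, so neither can be given a cause.

Open, as far as these compounds go, is how the number moves along the phenyl substituent between methyl and ethoxy, and whether a propyl chain, a hydroxyl, an amine or a carboxylic acid in the same place would stand with compound 4 or with compound 1. Also open, from the compounds shown here alone, is whether ethoxy has the same size of effect on a benzyl group, where only the methoxy of compound 3 gives a reading.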